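Halogen swap on the indole ring: fluoro to chloro

This account rests on a few compounds, and the source may have more. Where it says the series, first, only, none or still open, it means among the compounds named here.

Compound 3 `Fc1ccc2[nH]c(-c3nc(-c4ccccc4)no3)cc2c1` carries fluoro on the benzene part of the shared core and a phenyl on the oxadiazole; in a functional assay on Jurkat cells (Homo sapiens) for antiproliferative activity, read by WST assay, with a stated time of 72 h (a lower number here means a stronger inhibitor, a higher number a weaker inhibitor), compound 3 gives 33800 nM. Compound 1 `Cc1noc(-c2cc3cc(Cl)ccc3[nH]2)n1`, with chloro on the same ring and methyl on the oxadiazole, gives 21600 nM, which sits within the scatter of compound 3, so no order between the two is claimed. Compound 2 `COc1ccc2[nH]c(-c3nc(-c4ccccc4)no3)cc2c1` returns only a limit, > 50000 nM, matching (the limit of > 50000 nM in this assay, at which 1 of the 3 values shown sits). Among the compounds with values here, the one measured step, an at least 1.4-fold lower number from compound 2 to compound 3 (0.17 log units; that floor lies within the scatter), has a floor within the scatter and so says little about the size of a halogen effect.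

Compound 4 `Clc1ccc2[nH]c(-c3nc(-c4ccccc4)no3)cc2c1` differs from compound 3 by chloro in place of fluoro on an aromatic carbon. Within the data shown here, no measured step covers fluoro against chloro directly; the only hint is compound 1, whose chloro on the same ring with a different oxadiazole substituent gives 21600 nM, near compound 3. The expectation is therefore a step of a 1.5-fold lower number from compound 3 to compound 4 (0.19 log units; within the scatter), which is no change beyond the scatter, with a slight lean toward a lower number. Compound 4 is estimated at 22000 nM, within 8000 nM to 60000 nM.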

Compound 4, half-maximal inhibitory concentration: > 50000 nM
Compound 4: only a limit was reported; the forecaster's own chance of this, stated with the estimate: 15%; middle value at least 2.2-fold (0.35 log units) from the limit.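

Compound 4 returns only a limit, > 50000 nM, in this assay, so its step from compound 2, itself a limit, cannot be read. On an aromatic carbon of the shared core, chloro in place of fluoro gives an at least 1.4-fold higher number from compound 3 to compound 4 (0.17 log units; that floor lies within the scatter): with phenyl on the oxadiazole, this swap brings no lower number, although the floor of the step leaves its true size unknown. Within the data shown here, the new information comes from the other place of difference, since with chloro held constant, phenyl in place of methyl gives an at least 2.3-fold higher number from compound 1 to compound 4 (0.36 log units; beyond the scatter), the first step in this set to lie beyond the scatter, and it shows that the phenyl on the oxadiazole, not chloro alone, separates these two compounds.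

Going by these compounds, how far chloro and methoxy lie apart with phenyl on the oxadiazole stays unresolved, and any further rise in the number is hidden at this ceiling: the limit of > 50000 nM in this assay, at which 2 of the 4 values shown sit. Also open is whether the step from methyl to phenyl holds with fluoro on the ring, and how an amine or a longer alkyl chain in that place on the oxadiazole would read.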